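A Chlorine Swap on a Weak Sigma Binder

The compounds below may be only part of what the source reports. "The series", "measured", "known", "first", "only" and "open" are said of these compounds alone.

Of the compounds shown here, two have been measured in an assay on membranes from liver for displacement of a labelled ligand from Sigma non-opioid intracellular receptor 1 (Rattus norvegicus), read by scintillation counting; a lower number here means a stronger inhibitor, a higher number a weaker inhibitor. Compound 1 `Cc1ccc(CN(C)CCCn2c(=O)oc3ccccc32)c(C)c1` gives 1830 nM, while compound 2 `O=C(Nc1ccccc1)C1CCN(Cc2ccccc2)CC1` gives 48.1 nM. Compound 1 thus has the higher of the two numbers and is the weaker inhibitor, and its gap to compound 2 lies beyond the usual scatter of repeated measurements. Within the data shown here, no two compounds here differ in only one place, so no single structural change has yet been tied to a measured step.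

Compound 3 `CN(CCCn1c(=O)oc2ccccc21)Cc1ccc(Cl)cc1` is the next candidate. It differs from compound 1 in one place: 4-chlorophenyl in place of 2,4-dimethylphenyl on a saturated chain carbon bound to an amine nitrogen. The shared core and the chain leading to the amine nitrogen are kept.

Without a measured step of this kind, the expected size is uncertain; the expected outcome is a 2.6-fold lower number from compound 1 to compound 3 (0.42 log units; beyond the scatter), a modest move toward a lower number that may not exceed the scatter. Compound 3 is estimated to give 700 nM, within a range from 200 nM to 2500 nM.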

Compound 3, inhibition constant: 1150 nM
The estimate for compound 3 lay 1.6-fold (0.22 log units) below the measured number, and the stated range covers the measured number.
By their numbers in this assay, from the lowest: compound 2; then compounds 3 and 1 (each within the scatter of the next).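

Among these compounds, the swap of 2,4-dimethylphenyl for 4-chlorophenyl, on a saturated chain carbon bound to an amine nitrogen, is the first single change that can be read here: in this assay it gives a 1.6-fold lower number from compound 1 to compound 3 (0.20 log units; within the scatter). The two compounds therefore cannot be told apart in this assay, and at this position one of these two aromatic groups can stand in for the other without a change that rises above the noise of repeated measurements. No measurement shown here offers an explanation for this close match.

A single step at one position gives no trend. From the compounds shown here alone, whether an unsubstituted phenyl, a 4-methoxyphenyl or a longer chain leading to the amine nitrogen would move the number beyond the scatter remains open.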